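The source may hold more compounds than are shown below. What is called first, only, known or untested is meant among the compounds shown, and "the series" means these compounds.

Three compounds share one core and differ only in the group on an aromatic carbon next to the ring nitrogen. In an assay on cells for antagonist activity at transient receptor potential cation channel subfamily V member 1 (Homo sapiens), read by FLIPR and calcium flux, with a stated time of 6 min (on this read-out higher numbers stand for weaker inhibition and lower numbers for stronger inhibition), compound 1 `CC(C(=O)NCc1ccc(C(C)(C)C)nc1N1CCCC1)c1ccc(NS(C)(=O)=O)c(F)c1` gives 1.2 nM, the highest of the three numbers. Compound 2 `CCC1CCN(c2nc(C(C)(C)C)ccc2CNC(=O)C(C)c2ccc(NS(C)(=O)=O)c(F)c2)CC1` gives 0.1 nM in this assay, and compound 3 `CC(C)COc1nc(C(C)(C)C)ccc1CNC(=O)C(C)c1ccc(NS(C)(=O)=O)c(F)c1` gives 0.6 nM. The steps are a 12-fold lower number from compound 1 to compound 2 (1.08 log units; beyond the scatter) and a 2.0-fold lower number from compound 1 to compound 3 (0.30 log units; within the scatter); between the other two compounds there is a 6.0-fold higher number from compound 2 to compound 3 (0.78 log units; beyond the scatter).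

Compound 4 `CC(C(=O)NCc1ccc(C(C)(C)C)nc1SCCCN(C)C)c1ccc(NS(C)(=O)=O)c(F)c1` has not yet been measured. It differs from compound 1 in one place: (3-(dimethylamino)propyl)sulfanyl in place of pyrrolidin-1-yl on an aromatic carbon. Among the measured compounds shown here, no measured step swaps the pyrrolidin-1-yl for an open chain carrying sulfur and a dimethylamino group, so the measured steps bear on it only indirectly. Exchanging the ring for a larger ring gave the large step of a 12-fold lower number from compound 1 to compound 2 (1.08 log units; beyond the scatter), while exchanging it for the isobutoxy chain gave a 2.0-fold lower number from compound 1 to compound 3 (0.30 log units; within the scatter), within the scatter. The entering group is a chain rather than a ring, so the isobutoxy comparison seems the closer one, and a step of a 1.2-fold lower number from compound 1 to compound 4 (0.08 log units; within the scatter) is expected, small and quite possibly within the scatter. Compound 4 is therefore estimated at 1 nM in this assay, with a range from 0.3 nM to 4 nM.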

Compound 4, inhibition constant: 51.8 nM
Beside the measured number, compound 4's estimate is 52-fold (1.71 log units) below it; measured number above the stated range.
By their numbers in this assay, from the lowest: compound 2; then compounds 3 and 1 (each within the scatter of the next); then compound 4.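

In this assay, among the compounds shown here, the group on this aromatic carbon next to the ring nitrogen had so far either lowered the number or left it within the scatter, but (3-(dimethylamino)propyl)sulfanyl gives a 43-fold higher number from compound 1 to compound 4 (1.64 log units; beyond the scatter) and so shows that a change here can greatly weaken inhibition. The gap widens against the other two groups, with an 86-fold higher number from compound 3 to compound 4 (1.94 log units; beyond the scatter) and a 520-fold higher number from compound 2 to compound 4 (2.71 log units; beyond the scatter), and since compound 3 also carries an open chain, having a chain rather than a ring is not enough on its own to bring such a loss. No available evidence explains this loss.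

The compounds shown leave open whether the loss goes with the sulfur, the dimethylamino group or the chain as a whole. A butylsulfanyl chain, which has no amine, and a 3-(dimethylamino)propoxy chain, which has oxygen in place of sulfur, would help to separate these.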